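The source may hold more compounds than are shown below. What is called first, only, known or untested is meant among the compounds shown, and "the series" means these compounds.

Measured so far in a functional assay on the whole organism for inhibition, with Lepidium sativum as the target; a lower number here means a stronger inhibitor, a higher number a weaker inhibitor:
- compound 1 `COC1=C(N)C(=O)c2c(ccnc2-c2ccccc2)C1=O` gives 11300 nM
- compound 2 `COC1=C(N)C(=O)c2c(ccnc2-c2ccccn2)C1=O` gives 12700 nM

Compound 1 stands at the lowest of the two numbers in this assay; its nearest neighbour is compound 2, and the difference between them is a 1.1-fold higher number from compound 1 to compound 2 (0.05 log units; within the scatter), so the two are not separated by the assay. That one measured step exchanges the aryl group on the shared core for a pyridinyl ring and shows that this exchange leaves the read-out essentially where it was.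

Compound 3 `COC1=C(N)C(=O)c2c(ccnc2-c2ccc([N+](=O)[O-])cc2)C1=O` is not yet measured. Relative to compound 1 the change is nitro in place of hydrogen on an aromatic carbon. Among the measured compounds shown here, no measured step touches a substituent on that aryl ring, so there is no direct precedent for this change in the data; the only measured step, from compound 1 to compound 2, concerns the ring itself and was within the scatter. For the measured compounds named here, nothing in hand therefore points to a shift beyond the scatter in this assay in either direction, and the expectation rests on the small reach of the one step known.

Compound 3 is accordingly expected near 11000 nM in this assay, with a range from 4000 nM to 30000 nM, the expected step from compound 1 being a 1.0-fold lower number from compound 1 to compound 3 (0.01 log units; within the scatter).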

Compound 3, half-maximal inhibitory concentration: 9410 nM
Estimate against measurement, compound 3: 1.2-fold (0.07 log units) above; low and high end bracket the measured number.
By their numbers in this assay, from the lowest: compounds 3, 1 and 2 (each within the scatter of the next).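

In this assay, among the compounds shown here, the one change made on the aryl ring itself, nitro in place of hydrogen on an aromatic carbon para to a large group, gives a 1.2-fold lower number from compound 1 to compound 3 (0.08 log units; within the scatter) and so stays within the scatter. This shows that the position tolerates a substituent of three heavy atoms, with two hydrogen-bond acceptors and no net charge, without any separation in this assay. The step from compound 1 to compound 2 could not show this, as it exchanged the ring and added no substituent to it. No measured information at hand bears on why the read-out holds here.

Going by these compounds, whether this tolerance extends to other groups at the same carbon stays open: an amine, a carboxylic acid or a longer chain could still move the number beyond the scatter, and compounds 1, 2 and 3 give no sign of the direction. Also open, on these data alone, is whether nitro on the pyridin-2-yl ring of compound 2 would behave as it does on the phenyl ring of compound 1, so the flat reading so far holds only for these three compounds.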